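Replacing the nitrile of compound 1 with an ethylamide

The compounds below may be only part of what the source reports. "The series", "measured", "known", "first", "only" and "open" are said of these compounds alone.

Compound 1 `N#CCCCc1c[nH]c2ccc(F)cc12`: in an assay on isolated protein (urine) for inhibition of Myeloperoxidase (Homo sapiens), with a stated time of 5 min (on this read-out higher numbers stand for weaker inhibition and lower numbers for stronger inhibition), compound 1 gives 63 nM
Compound 2 `NC(=O)CCCc1c[nH]c2ccc(F)cc12`: in this assay compound 2 gives 18 nM
Compound 3 `NCCSCCc1c[nH]c2ccc(F)cc12`: in this assay compound 3 gives 4 nM

Among these three, compound 1 shows the highest number, so it is the weakest inhibitor of the set. Compound 2 sits a 3.5-fold lower number from compound 1 to compound 2 (0.54 log units; beyond the scatter), and compound 3 sits a 16-fold lower number from compound 1 to compound 3 (1.20 log units; beyond the scatter); between them, compound 3 lies a 4.5-fold lower number from compound 2 to compound 3 (0.65 log units; beyond the scatter).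

Compound 4 `CCNC(=O)CCCc1c[nH]c2ccc(F)cc12` has not been measured. It differs from compound 1 in one place: ethylcarbamoyl in place of cyano on a saturated chain carbon, three bonds along the chain from an aromatic carbon. The closest measured comparison is the step from compound 1 to compound 2, where a carbamoyl replaced the cyano group at the same place and gave a 3.5-fold lower number from compound 1 to compound 2 (0.54 log units; beyond the scatter). Within the data shown here, compound 4 carries the same amide with an ethyl on its nitrogen, so a change of similar size and direction in this assay is expected, with no measured compound to show what the ethyl adds. The expected step is a 2.9-fold lower number from compound 1 to compound 4 (0.46 log units; beyond the scatter). Compound 4 is therefore estimated at 22 nM, within a range of 8 nM to 60 nM.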

Compound 4, half-maximal inhibitory concentration: 182 nM
For compound 4 the middle estimate is 8.3-fold (0.92 log units) below the measured one, and the stated range ends below it.
By their numbers in this assay, from the lowest: compound 3; then compound 2; then compound 1; then compound 4.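

In this assay, where a higher number means weaker inhibition, the amide at this place does not accept every change: ethyl in place of the amide hydrogen gives a 10-fold higher number from compound 2 to compound 4 (1.00 log units; beyond the scatter) and undoes the gain of the plain carbamoyl. Ethylcarbamoyl in place of cyano therefore moves the number the opposite way to carbamoyl, with a 2.9-fold higher number from compound 1 to compound 4 (0.46 log units; beyond the scatter) as the result, so this position responds to what sits on the amide nitrogen and not only to the presence of an amide. The gap to the (2-aminoethyl)sulfanyl chain also widens, with a 46-fold higher number from compound 3 to compound 4 (1.66 log units; beyond the scatter) separating the two, and compound 4 is the weakest inhibitor of the four.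

Nothing available gives a reason for the loss seen with the ethyl. As far as these compounds go, whether a smaller methyl on the amide nitrogen costs less, and how a carboxylic acid at this chain end would compare, stays open.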